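Fluorinated carboxyphenyl ether on a second core

The compounds below may be only part of what the source reports. "The series", "measured", "known", "first", "only" and "open" are said of these compounds alone.

Measured compounds:
compound 1 `Cc1c(OCCCCOc2ccccc2C(=O)O)ccc(C(=O)CC2CCCC2)c1C` — 67.1%
compound 2 `Cc1c(OCCCCOc2ccc(F)c(C(=O)O)c2)ccc(C(=O)CC2CCCC2)c1C` — 14.6%
compound 3 `Cc1c(OCCCCOc2ccccc2C(=O)O)ccc(C(=O)CC(C)C)c1O` — 92.4%

In an assay on HEK293 cells for positive allosteric modulation of metabotropic glutamate receptor 2 (Rattus norvegicus), read by thallium flux, with a stated time of 2.5 min (on this read-out higher numbers stand for larger maximal responses and lower numbers for smaller maximal responses), compound 3 stands highest of the three, with compound 1 lower and compound 2 lowest. The change from compound 1 to compound 2, (3-carboxy-4-fluorophenyl in place of 2-carboxyphenyl on an oxygen on a saturated carbon), produced a number 52.5 percentage points lower from compound 1 to compound 2 (beyond the scatter). Compound 4 `Cc1c(OCCCCOc2ccc(F)c(C(=O)O)c2)ccc(C(=O)CC(C)C)c1O` is not yet measured; it carries the same change on the core of compound 3, namely (3-carboxy-4-fluorophenyl in place of 2-carboxyphenyl on an oxygen on a saturated carbon), and the two places are described in the same words. How the core of compound 3 differs from the core of compound 1 is not broken down here.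

Because the step of a number 52.5 percentage points lower from compound 1 to compound 2 (beyond the scatter) was large and beyond the scatter, compound 4 is expected to fall well below compound 3, with an estimated a number 60.4 percentage points lower from compound 3 to compound 4 (beyond the scatter). Whether the drop carries over to the second core rests on one pair alone, so the expectation is uncertain. Compound 4 is estimated at 32%, between 10% and 60% in this assay.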

Compound 4, largest response reached (reported as percent of maximum), in percent of the reference or control that the assay uses: 84.5%
Compound 4: middle estimate off by 52.5 percentage points, on the low side; measured number above the stated range.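

On the second core, putting 3-carboxy-4-fluorophenyl in place of 2-carboxyphenyl gave, in this assay, a number 7.9 percentage points lower from compound 3 to compound 4 (within the scatter), so the large loss seen on the first core did not recur. The two steps differ, and the result of this change on one core did not predict its result on the other: the same change on two cores in this assay, a number 52.5 percentage points lower (beyond the scatter) from compound 1 to compound 2 and a number 7.9 percentage points lower (within the scatter) from compound 3 to compound 4, 44.6 percentage points apart, beyond the scatter of two such steps. This shows that in this series the outcome of the change depends on the core that carries it, but with a single pair on each core it does not show which feature of the cores decides the outcome, nor how any other core would respond.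

The compounds shown leave open whether a 3-carboxyphenyl group without the fluorine would behave like 3-carboxy-4-fluorophenyl on either core. They also leave open how a chlorine in place of the fluorine, or a tetrazole in place of the carboxylic acid, would fare on these two cores.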